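Methyl Added to a Bare Bicyclic Core

The compounds below may be only part of what the source reports. "The series", "measured", "known", "first", "only" and "open" are said of these compounds alone.

Compound 2 `c1ccc(-n2cc3cnccc3n2)cc1` stands at the edge of what this study could resolve. In a functional assay on MCF7 cells (Homo sapiens) for inhibition, read by fluorescence, with a stated time of 72 h (a higher number here means a weaker inhibitor of growth, a lower number a stronger inhibitor of growth), compound 2 gives only the limit > 100000 nM, which is a boundary of the assay and not a measured number. the limit of > 100000 nM in this assay, at which 1 of the 2 values shown sits, describes where compound 2 sits. A more substituted relative on the shared core, compound 1 `Cc1nc(C2CC2)cc2nn(-c3ccccc3)cc12`, does return a number and gives 63500 nM in this assay. Compound 3 `Cc1nccc2nn(-c3ccccc3)cc12` has not yet been measured. Relative to compound 2 it differs by methyl in place of hydrogen on an aromatic carbon. Within the data shown here, no step between measured compounds connects these two, so only an expectation can be offered: a move toward somewhat stronger growth inhibition in this assay, of a size that may well stay within the scatter. Compound 3 is expected to give about 90000 nM, within 40000 nM and 200000 nM, so the step of an at least 1.1-fold lower number from compound 2 to compound 3 (0.04 log units; that floor lies within the scatter) is estimated to be modest.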

Compound 3, concentration for 50% growth inhibition: > 100000 nM
Compound 3: a limit, no number (the forecaster's own chance of this, stated with the estimate: 50%); middle value at least 1.1-fold (0.04 log units) from the limit.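

With methyl on the aromatic carbon next to the ring nitrogen, compound 3 still returns only a limit in this assay, so methyl alone does not bring this bare core to a readable number, and the step between the two limits cannot be read: the limit of > 100000 nM in this assay, at which 2 of the 3 values shown sit. Among these compounds, the one step that can be read, an at least 1.5-fold higher number from compound 1 to compound 3 (0.19 log units; that floor lies within the scatter), comes with hydrogen in place of cyclopropyl on an aromatic carbon. Since its floor stays within the scatter, the data do not yet establish how much the cyclopropyl adds to growth inhibition.

What the compounds shown leave open is whether a different group on the methyl carbon, such as an amine or a longer chain, would give a number at all. Going by these compounds, it is equally open whether a carboxylic acid in place of the cyclopropyl would keep the value of compound 1.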